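The compounds below may be only part of what the source reports. "The series", "measured", "known", "first", "only" and "open" are said of these compounds alone.

Compound 1 `CCC(COc1ccccc1Cl)OC(=O)NCc1ccccc1`, compound 2 `CCC(COc1ccc(Cl)cc1)OC(=O)NCc1ccccc1` and compound 3 `CCC(COc1cccc(F)c1)OC(=O)NCc1ccccc1` share one core and differ only in the aromatic ring carried on the oxygen. In an assay for inhibition of zeta-carotene desaturase, chloroplastic/chromoplastic (Capsicum annuum), using a Dixon plot, with a stated time of 8 h (on this read-out higher numbers stand for weaker inhibition and lower numbers for stronger inhibition), compound 1 gives > 100000 nM, which is a limit of the assay and not a number. In this assay compound 2 likewise reaches only a limit, > 100000 nM. Compound 3 also stands at a limit, > 100000 nM. All three values sit at the limit of > 100000 nM in this assay, at which 3 of the 3 values shown sit, so the steps a step that the two limits leave unreadable from compound 1 to compound 2, a step that the two limits leave unreadable from compound 1 to compound 3 and a step that the two limits leave unreadable from compound 2 to compound 3 cannot be read in size or direction. Compound 4 `CCC(COc1cccc(C(C)C)c1)OC(=O)NCc1ccccc1` differs from compound 3 by isopropyl in place of fluoro on an aromatic carbon. Within the data shown here, no measured step has a readable size, so none bears on this change. Compound 4 is expected to give about 100000 nM, between 20000 nM and 300000 nM, most likely again as a limit, an expected step of a number no higher from compound 3 to compound 4 (the limit leaves the size open).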

Compound 4, half-maximal inhibitory concentration: > 100000 nM
Compound 4: a limit, no number; the forecaster's own chance of this, stated with the estimate: 75%; the middle value sits exactly at the limit.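

Compound 3 and compound 4 both stand at a limit, so the step between them cannot be read in size or direction. The compounds shown leave open whether any group on this aromatic ring gives a measurable value in this assay.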